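The source may report more compounds than this note shows. Statements on the series, on what has been measured and on what is new or still open speak of the compounds shown alone.

Measured compounds in a functional assay on CNE-2 cells (Homo sapiens) for cytotoxicity, read by MTT assay, with a stated time of 72 h; a lower number here means a stronger inhibitor, a higher number a weaker inhibitor:

compound 1, `O=C(NC(=S)NNc1ncnc2ccccc12)c1ccc(Cl)cc1`, gives 1530 nM
compound 2, `O=C(NC(=S)NNc1ncnc2ccccc12)c1cccc(Cl)c1`, gives 2920 nM

Going by the values given here, compound 2 carries the highest of the two numbers so far in this assay; its nearest neighbour is compound 1, and the only measured step, a 1.9-fold higher number from compound 1 to compound 2 (0.28 log units; within the scatter), is within the scatter, so the two values cannot be placed in order.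

Compound 3, `Cc1ccc(C(=O)NC(=S)NNc2ncnc3ccccc23)cc1`, has not yet been measured. Its difference from compound 2 is 4-methylphenyl in place of 3-chlorophenyl on a carbonyl carbon.

Among the compounds with values here, no measured step covers an exchange of chlorine for methyl on this aryl group. Within the data shown here, the single step that bears on it at all is a 1.9-fold higher number from compound 1 to compound 2 (0.28 log units; within the scatter): the same aryl group on the same carbonyl carbon was altered there, and the number did not move beyond the scatter. Among the measured compounds shown here, with that as the only guide, no step beyond the scatter is expected from compound 2 to compound 3 in this assay; the expected step is a 1.3-fold lower number from compound 2 to compound 3 (0.12 log units; within the scatter).

For compound 3 the estimate in this assay is therefore 2200 nM, with an expected range from 800 nM to 6000 nM.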

Compound 3, half-maximal inhibitory concentration: 17200 nM
For compound 3 the middle estimate is 7.8-fold (0.89 log units) below the measured one; measured number outside the range, above it.
By their numbers in this assay, from the lowest: compounds 1 and 2 (each within the scatter of the next); then compound 3.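

In this assay, the aryl group on the carbonyl carbon proves less forgiving than the first two compounds suggested: exchanging 3-chlorophenyl for 4-methylphenyl gives a 5.9-fold higher number from compound 2 to compound 3 (0.77 log units; beyond the scatter) and so moves the number beyond the scatter, which the shift between the two chlorophenyl groups did not do. Going by these compounds alone, the comparison between 4-chlorophenyl and 4-methylphenyl, with methyl in place of chloro on an aromatic carbon, gives an 11-fold higher number from compound 1 to compound 3 (1.05 log units; beyond the scatter) and is the largest step so far, so the group carried by the ring matters here and not only where it stands. Across these three compounds, the two chlorine-bearing compounds lie within the scatter of each other while the methyl-bearing compound 3 stands apart, a pattern that rests on a single methyl example.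

No available evidence accounts for this difference between chloro and methyl. Still open, on these data alone, is whether an unsubstituted phenyl, a methoxy group, a fluorine or an amine on this ring would sit with compound 1 and compound 2 or with compound 3, and whether 3-methylphenyl would behave like 4-methylphenyl.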